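This account rests on a few compounds, and the source may have more. Where it says the series, first, only, none or still open, it means among the compounds named here.

Going by the values given here, compound 3 `Cc1cc(C(=O)NCN2CCC(c3cccc[n+]3[O-])CC2)ccc1Cl` stands at the top of the numbers so far in a functional assay on HEK293 cells for agonist activity at D(4) dopamine receptor (Homo sapiens), read by FLIPR (on this read-out lower numbers stand for an effect already at smaller amounts and higher numbers for an effect only at larger amounts of compound), where compound 3 gives 2460 nM. Its two neighbours sit far lower: compound 1 `Cc1cccc(C(=O)NCN2CCC(c3cccc[n+]3[O-])CC2)c1` gives 89 nM and compound 2 `Cc1cc(C)cc(C(=O)NCN2CCC(c3cccc[n+]3[O-])CC2)c1` gives 90 nM, and a 1.0-fold higher number from compound 1 to compound 2 (0.00 log units; within the scatter) shows that those two cannot be told apart. The costly move is the chloro: a 28-fold higher number from compound 1 to compound 3 (1.44 log units; beyond the scatter) and a 27-fold higher number from compound 2 to compound 3 (1.44 log units; beyond the scatter) both record a large loss.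

Compound 4 `Cc1ccc(C(=O)NCN2CCC(c3cccc[n+]3[O-])CC2)cc1C` differs from compound 3 by methyl in place of chloro on an aromatic carbon. Among the compounds with values here, two measured steps bear on this. The step of a 28-fold higher number from compound 1 to compound 3 (1.44 log units; beyond the scatter) says that a chloro on that aromatic carbon is what set compound 3 apart, so removing it should recover part of that loss. The step of a 1.0-fold higher number from compound 1 to compound 2 (0.00 log units; within the scatter), methyl in place of hydrogen on an aromatic carbon, says that a methyl elsewhere on the same ring changed nothing beyond the scatter; whether a methyl on this carbon behaves like hydrogen or like chloro is not settled by any measured pair. A downward step of middling size is therefore expected for compound 4, a 4.9-fold lower number from compound 3 to compound 4 (0.69 log units; beyond the scatter), short of a full return to the level of compound 1. Compound 4 is estimated at 500 nM, with a range from 120 nM to 2500 nM.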

Compound 4, half-maximal effective concentration: 38 nM
Compound 4: middle estimate off by 13-fold (1.12 log units), on the high side, outside the stated range (below it).
By their numbers in this assay, from the lowest: compound 4; then compounds 1 and 2 (each within the scatter of the next); then compound 3.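

The swap at this carbon, para to a large group and ortho to a methyl group, separates two groups of one heavy atom sharply in this assay: a 65-fold lower number from compound 3 to compound 4 (1.81 log units; beyond the scatter), so the high number belongs to chloro and not to having any group on this carbon. Methyl here is more than tolerated, since a 2.3-fold lower number from compound 1 to compound 4 (0.37 log units; beyond the scatter), a modest step beyond the scatter, whereas the methyl added on another carbon of the ring left the number within the scatter, and a 2.4-fold lower number from compound 2 to compound 4 (0.37 log units; beyond the scatter) likewise shows that the 3,4-dimethylphenyl and 3,5-dimethylphenyl patterns can be told apart. Nothing available explains why chloro and methyl part so widely on this carbon.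

On these data alone, whether the high number is peculiar to chloro remains open, as fluoro, methoxy, ethyl or trifluoromethyl on this same carbon would be needed to show how far the effect extends. Going by these compounds alone, it also remains open whether chloro and methyl would differ as widely without the neighbouring methyl, as a plain 4-chlorophenyl and 4-methylphenyl pair would test, or on a core other than the one all four compounds share.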